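Aryl ether variation and PBMC tolerability in the series

The source may hold more compounds than are shown below. What is called first, only, known or untested is meant among the compounds shown, and "the series" means these compounds.

Compound 1 `COc1cccc(OC(c2ccc(C(F)(F)F)cc2)C2CCN(C(C)CCNC(=O)c3c(Cl)cncc3Cl)CC2)n1`: 32700 nM
Compound 2 `Cc1cccnc1OC(c1ccc(C(F)(F)F)cc1)C1CCN(C(C)CCNC(=O)c2c(Cl)cncc2Cl)CC1`: 33000 nM
Compound 3 `CC(CCNC(=O)c1c(Cl)cncc1Cl)N1CCC(C(Oc2ccccc2C(F)(F)F)c2ccc(C(F)(F)F)cc2)CC1`: 12500 nM

In an ADME assay on PBMC cells (Homo sapiens) for cytotoxicity (a higher number here means that more compound is tolerated, a lower number that less compound is tolerated), compound 3 stands lowest of the three. Compounds 1 and 2 lie within the scatter of each other, as a 1.0-fold higher number from compound 1 to compound 2 (0.00 log units; within the scatter) shows. Compound 3 sits apart from both: a 2.6-fold lower number from compound 1 to compound 3 (0.42 log units; beyond the scatter) and a 2.6-fold lower number from compound 2 to compound 3 (0.42 log units; beyond the scatter), each modest but beyond the scatter. Compound 4 `COC(=O)c1cccc(OC(c2ccc(C(F)(F)F)cc2)C2CCN(C(C)CCNC(=O)c3c(Cl)cncc3Cl)CC2)c1` has not yet been measured in this assay. The change is 3-(methoxycarbonyl)phenyl in place of 2-(trifluoromethyl)phenyl on an oxygen on a saturated carbon. Within the data shown here, both measured steps that bear on this ran toward 2-(trifluoromethyl)phenyl and lowered the number; here that group leaves, so a modest rise back toward compounds 1 and 2 is expected, though the entering group has no measured precedent. Compound 4 is estimated at 25000 nM, between 12000 nM and 50000 nM, which would mean a 2.0-fold higher number from compound 3 to compound 4 (0.30 log units; within the scatter).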

Compound 4, half-maximal cytotoxic concentration: 15200 nM
Compound 4: middle estimate off by 1.6-fold (0.22 log units), on the high side; low and high end bracket the measured number.
By their numbers in this assay, from the lowest: compounds 3 and 4 (each within the scatter of the next); then compounds 1 and 2 (each within the scatter of the next).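

In this assay the 3-(methoxycarbonyl)phenyl group on the oxygen cannot be told apart from 2-(trifluoromethyl)phenyl (a 1.2-fold higher number from compound 3 to compound 4 (0.08 log units; within the scatter)). Against the pyridin-2-yl groups it gives (a 2.2-fold lower number from compound 2 to compound 4 (0.34 log units; beyond the scatter)) and (a 2.2-fold lower number from compound 1 to compound 4 (0.33 log units; beyond the scatter)), so across these four compounds both groups with an aromatic ring of carbon only sit below both pyridin-2-yl groups, and no compound goes against this. No evidence on hand accounts for this split.

Open, from the compounds shown here alone, is whether the ring type or its substituents set this split. An unsubstituted phenyl, or a carboxylic acid or an amine in place of the methyl ester, would test this in this assay.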